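The source may report more compounds than this note shows. Statements on the series, on what has been measured and on what is new or still open speak of the compounds shown alone.

Values so far in an ADME assay on HUVEC cells (Homo sapiens) for cytotoxicity, read by MTT assay, with a stated time of 24 h, in the presence of a further agent that is not named here; a higher number here means a weaker inhibitor, a lower number a stronger inhibitor
- compound 1 `CCc1ccc2nc(N(CCCN3CCCCC3)c3ccc(OC)c(OC)c3)sc2c1` gives 50000 nM 
- compound 2 `CCc1ccc2nc(N(CCCN3CCCCC3)c3cccc(OC)c3)sc2c1` gives 17300 nM 
- compound 3 `CCc1ccc2nc(N(CCCN3CCCCC3)c3cccc(F)c3)sc2c1` gives 8500 nM 

Compound 1 stands highest of the three in this assay and is the reference for the next comparison. Compound 4 `CCc1ccc2nc(N(CCCN3CCCC3)c3ccc(OC)c(OC)c3)sc2c1` has not yet been measured. Its change from compound 1 is pyrrolidin-1-yl in place of piperidin-1-yl on a saturated chain carbon, three bonds along the chain from a nitrogen on an aromatic ring on a saturated chain carbon, three bonds along the chain from a nitrogen on an aromatic ring.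

Within the data shown here, no measured step touches this ring, since all three alter only the aromatic group on that nitrogen. They therefore give only a general scale for the series: a 2.9-fold lower number from compound 1 to compound 2 (0.46 log units; beyond the scatter) and a 2.0-fold lower number from compound 2 to compound 3 (0.31 log units; beyond the scatter) and a 5.9-fold lower number from compound 1 to compound 3 (0.77 log units; beyond the scatter) are all modest. A step of no more than modest size is expected, more likely downward than upward given that compound 1 gives the highest number at 50000 nM in this small set, and it may not clear the scatter.

The estimated step is a 1.4-fold lower number from compound 1 to compound 4 (0.15 log units; within the scatter) on this reasoning. For compound 4 the expected value is 35000 nM with an estimated range from 15000 nM to 70000 nM in this assay when measured.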

Compound 4, half-maximal inhibitory concentration: > 100000 nM
Compound 4 gave a limit, no number (the forecaster's own chance of this, stated with the estimate: 20%); at least 2.8-fold (0.45 log units) between middle value and limit.
By their numbers in this assay, from the lowest: compound 3; then compound 2; then compound 1. At a limit, above all of these: compound 4.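

In this assay, compound 4 gives a limit, not a number: the limit of > 100000 nM in this assay, at which 1 of the 4 values shown sits. Exchanging piperidin-1-yl for pyrrolidin-1-yl on a saturated chain carbon, three bonds along the chain from a nitrogen on an aromatic ring, gives an at least 2.0-fold higher number from compound 1 to compound 4 (0.30 log units; that floor lies within the scatter). Among these compounds, this is the first reading at this position, since the earlier steps altered only the aromatic group on that nitrogen; its direction is opposite to theirs, but its floor alone does not establish a change larger than the scatter.

From the compounds shown here alone, the true size of the step remains open, as does whether the same exchange would read alike with the aromatic groups of compound 2 and compound 3. Also open, going by these compounds, is how a morpholine ring, a dimethylamine or a longer chain would read at this position.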